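Swapping the Ester for a Hydroxy on the Anilide Ring

A few compounds are considered here, and "the series" means these few. Any claim that something is new, unique, unknown or untested is made for them only; others in the source may bear on it.

Compound 1 `COC(=O)c1ccc(NC(=O)C2(C(=O)Nc3ccc(Nc4ncc5cc(C(=O)N(C)C)n(C6CCCC6)c5n4)cc3)CC2)cc1` has been tested in a functional assay on A549 cells (Homo sapiens) for inhibition, read by CCK-8 assay, with a stated time of 72 h, tested at 10 uM (on this read-out higher numbers stand for more inhibition of growth at the one concentration tested and lower numbers for less inhibition of growth), where compound 1 gives 92%. Two companions share its core and differ only at one aromatic carbon: compound 2 `CN(C)C(=O)c1cc2cnc(Nc3ccc(NC(=O)C4(C(=O)Nc5ccc(Cl)cc5)CC4)cc3)nc2n1C1CCCC1` gives 101% in this assay, and compound 3 `CN(C)C(=O)c1cc2cnc(Nc3ccc(NC(=O)C4(C(=O)Nc5ccc(C(F)(F)F)cc5)CC4)cc3)nc2n1C1CCCC1` gives 87.9%. On the bare numbers compound 1 is the second highest of the three, but both steps from it stay within the scatter: a number 9 percentage points higher from compound 1 to compound 2 (within the scatter) and a number 4.1 percentage points lower from compound 1 to compound 3 (within the scatter). Among the measured compounds shown here, the only step beyond the scatter is a number 13.1 percentage points lower from compound 2 to compound 3 (beyond the scatter), and it remains modest.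

Compound 4 `CN(C)C(=O)c1cc2cnc(Nc3ccc(NC(=O)C4(C(=O)Nc5ccc(O)cc5)CC4)cc3)nc2n1C1CCCC1` has not yet been measured. It arises from compound 1 by hydroxy in place of methoxycarbonyl on an aromatic carbon. The earlier exchanges at this same carbon bear on it: three different groups there moved the read-out only a little, so a small step is expected, and the data give no direction for it. The expected result for compound 4 is 88%, with a range from 72% to 100%. That amounts to an expected step of a number 4 percentage points lower from compound 1 to compound 4 (within the scatter), which should stay within the scatter.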

Compound 4, percent growth inhibition at one concentration: 94.4%
For compound 4 the middle estimate is 6.4 percentage points below the measured one, and the stated range covers the measured number.
By their numbers in this assay, from the lowest: compounds 3, 1, 4 and 2 (each within the scatter of the next, the first and the last beyond it).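

In this assay the exchange for hydroxy, a group with fewer heavy atoms than methoxycarbonyl and with a hydrogen-bond donor that methoxycarbonyl lacks, gives a number 2.4 percentage points higher from compound 1 to compound 4 (within the scatter) and so leaves the read-out in place. The two other groups tell the same story, with a number 6.5 percentage points higher from compound 3 to compound 4 (within the scatter) and with a number 6.6 percentage points lower from compound 2 to compound 4 (within the scatter) as well, so hydroxy stays within the scatter of all three groups tried at this carbon, even though compound 2 and compound 3 lie beyond the scatter of each other. Nothing measured here explains why such different groups give such similar numbers.

As far as these compounds go, all four compounds were read at a single concentration, so any differences that would appear at lower concentrations remain unknown. From the compounds shown here alone, it also stays open whether an amine, a carboxylic acid or a longer chain such as a butoxy group at this carbon would fit the same picture.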